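A few compounds are considered here, and "the series" means these few. Any claim that something is new, unique, unknown or untested is made for them only; others in the source may bear on it.

Measured so far:
Compound 1, `Cc1cccc(CNc2ncnc3c2ncn3[C@@H]2O[C@H](CO)[C@@H](O)[C@H]2O)c1`, in a functional assay on K562 cells (Homo sapiens) for antiproliferative activity, with a stated time of 72 h (a lower number here means a stronger inhibitor, a higher number a weaker inhibitor), gives only a limit of the assay, > 166000 nM.
Compound 2, `Cc1ccc(CNc2ncnc3c2ncn3[C@@H]2O[C@H](CO)[C@@H](O)[C@H]2O)cc1`, in this assay likewise gives only a limit, > 166000 nM.

Compound 2 therefore stands at the limit of this assay, not at a number, and the same is true of compound 1: the limit of > 166000 nM in this assay, at which 2 of the 2 values shown sit. For the measured compounds named here, the single measured step, a step that the two limits leave unreadable from compound 1 to compound 2, cannot be read in size for this reason.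

Compound 3, `OC[C@H]1O[C@@H](n2cnc3c(NCc4c(F)ccc(F)c4F)ncnc32)[C@H](O)[C@@H]1O`, differs from compound 2 in one place: 2,3,6-trifluorophenyl in place of 4-methylphenyl on a saturated chain carbon bound to a nitrogen on an aromatic ring. Going by the values given here, the only measured step touches the same saturated chain carbon bound to a nitrogen on an aromatic ring, but because both of its values are limits, as the limit of > 166000 nM in this assay, at which 2 of the 2 values shown sit, shows, it gives no readable size to carry over. No step beyond the scatter is therefore expected in this assay, and compound 3 is most likely to return a limit as well. The expected step is a number no higher from compound 2 to compound 3 (the limit leaves the size open), and the estimate for compound 3 is 166000 nM with a range from 40000 nM to 600000 nM.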

Compound 3, half-maximal inhibitory concentration: > 166000 nM
Compound 3: only a limit was reported; the forecaster's own chance of this, stated with the estimate: 80%; the middle value sits exactly at the limit.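

Compound 3 also gives only a limit, > 166000 nM, so its steps from compound 1 and compound 2 cannot be read in size: the limit of > 166000 nM in this assay, at which 3 of the 3 values shown sit.

The compounds shown leave open whether any group on this saturated chain carbon gives a readable number in this assay.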